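The source may hold more compounds than are shown below. What is called first, only, known or untested is meant among the compounds shown, and "the series" means these compounds.

Among the compounds with values here, in a functional assay on MDA-MB-231 cells (Homo sapiens) for cytotoxicity, read by MTT assay, with a stated time of 24 h (a lower number here means a stronger inhibitor, a higher number a weaker inhibitor), compound 1 (`CCCCCCCCCCCCCC(=O)Nc1nnc(S[C@@H]2O[C@H](COC(C)=O)[C@H](OC(C)=O)[C@H](OC(C)=O)[C@H]2OC(C)=O)s1`) gives 26200 nM and compound 2 (`CCCCCCCC(=O)Nc1nnc(S[C@@H]2O[C@H](CO)[C@H](O)[C@H](O)[C@H]2O)s1`) gives 30800 nM as the only numbers so far. These two values lie within the usual scatter of each other, so compound 1 cannot be ranked against compound 2 on this evidence.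

The next compound is compound 3 (`CCCCCCCCCCCCCCCCCC(=O)Nc1nnc(S[C@@H]2O[C@H](COC(C)=O)[C@H](OC(C)=O)[C@H](OC(C)=O)[C@H]2OC(C)=O)s1`). It differs from compound 1 by one change (butyl in place of hydrogen on a saturated chain carbon, ten or more bonds along the chain from a carbonyl carbon) in the acyl chain: butyl in place of hydrogen on a saturated chain carbon, ten or more bonds along the chain from a carbonyl carbon. The core of compound 1 and its acetyl groups stay as they are.

Within the data shown here, no measured pair isolates chain length, so the data give no direction for this change. Taking compound 1 at 26200 nM as the anchor, no step beyond the scatter is expected in this assay, and the expected move (a 1.2-fold higher number from compound 1 to compound 3 (0.09 log units; within the scatter)) is small, with a slight lean towards a higher number. The estimate for compound 3 is 32000 nM with an expected range of 14000 nM to 75000 nM in this reading.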

Compound 3, half-maximal inhibitory concentration: 23600 nM
Estimate against measurement, compound 3: 1.4-fold (0.13 log units) above; measured number inside the range.
By their numbers in this assay, from the lowest: compounds 3, 1 and 2 (each within the scatter of the next).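

In this assay, within the data shown here, butyl in place of hydrogen on a saturated chain carbon, ten or more bonds along the chain from a carbonyl carbon, gives a 1.1-fold lower number from compound 1 to compound 3 (0.05 log units; within the scatter), the first step that isolates a change in the acyl chain. With the core of compound 1 and its acetyl groups held fixed, this single extension therefore produces no readable change in the cytotoxicity read-out, although one step cannot establish a trend across chain lengths. Nothing measured alongside these compounds bears on this result.

Compound 2 differs from both compound 1 and compound 3 in more than one place, so the steps to it cannot be read, and the separate contributions of the chain and the acetyl groups remain unresolved. Also open, on these data alone, is whether the same position tolerates a chain longer than that of compound 3, or a terminal amine or carboxylic acid in place of the chain end, and whether either would move the number beyond the scatter.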